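The source may report more compounds than this note shows. Statements on the series, on what has been measured and on what is new or still open speak of the compounds shown alone.

Measured so far, in an assay on isolated protein for inhibition of 2-Hydroxyacid oxidase 1 (Homo sapiens), with stated times of 30 min and 15 min; on this read-out lower numbers stand for stronger inhibition and higher numbers for weaker inhibition:
- compound 1 `Cc1csc(-c2cccc(CNc3ccc4[nH]nc(C(=O)O)c4c3)c2O)n1`: 23 nM
- compound 2 `CC(C)c1csc(-c2cccc(CNc3ccc4[nH]nc(C(=O)O)c4c3)c2O)n1`: 65 nM
- compound 3 `CN(C)C(=O)c1cccc(CNc2ccc3[nH]nc(C(=O)O)c3c2)c1O`: > 30000 nM

Compound 3 stands apart from the other two. For compound 3 this assay gives only a limit, > 30000 nM, not a number; this is the limit of > 30000 nM in this assay, at which 1 of the 3 values shown sits. Compound 1 and compound 2 both give numbers well inside the measurable range, and the step of a 2.8-fold higher number from compound 1 to compound 2 (0.45 log units; beyond the scatter) is modest.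

The next compound, compound 4 `Cc1nc(-c2cccc(CNc3ccc4[nH]nc(C(=O)O)c4c3)c2O)sc1C`, returns to the pattern of compound 1 and compound 2: the change is 4,5-dimethyl-1,3-thiazol-2-yl in place of dimethylcarbamoyl on an aromatic carbon.

For the measured compounds named here, two measured steps bear on this change, both in the opposite direction. The step of an at least 1300-fold higher number from compound 1 to compound 3 (3.11 log units; beyond the scatter) and the step of an at least 460-fold higher number from compound 2 to compound 3 (2.66 log units; beyond the scatter) were both large, and both replaced a 1,3-thiazol-2-yl group by dimethylcarbamoyl. Compound 4 reverses that exchange, with a 4,5-dimethyl-1,3-thiazol-2-yl group entering. A large fall in number is therefore expected in this assay, of a size at least comparable to those two steps. The expected step is an at least 850-fold lower number from compound 3 to compound 4 (2.93 log units; beyond the scatter). Compound 4 is estimated at 35 nM, with a range from 10 nM to 150 nM, close to compound 1 and compound 2.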

Compound 4, half-maximal inhibitory concentration: 25 nM
Compound 4: the middle estimate sits 1.4-fold (0.15 log units) above what was measured; low and high end bracket the measured number.
By their numbers in this assay, from the lowest: compounds 1 and 4 (each within the scatter of the next); then compound 2. At a limit, above all of these: compound 3.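

Compound 3 remains a limit and not a number in this assay: the limit of > 30000 nM in this assay, at which 1 of the 4 values shown sits.

Measured against that limit, a third substituted 1,3-thiazol-2-yl group on the aromatic carbon ortho to the hydroxy group again gives a large step, an at least 1200-fold lower number from compound 3 to compound 4 (3.07 log units; beyond the scatter), so the advantage over dimethylcarbamoyl now holds across three substitution patterns on that ring, though its full size cannot be read. Within the ring, a further methyl makes no readable difference, a 1.1-fold higher number from compound 1 to compound 4 (0.04 log units; within the scatter), whereas exchanging 4-isopropyl for 4,5-dimethyl gives a modest step, a 2.6-fold lower number from compound 2 to compound 4 (0.41 log units; beyond the scatter), so the 4-isopropyl compound is the one exception to an otherwise flat picture among the thiazole compounds.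

How an unsubstituted 1,3-thiazol-2-yl, an oxazol-2-yl or a phenyl group would compare at this place remains open, so the shown compounds do not tell whether the sulfur-containing ring itself is required. Also open, from the compounds shown here alone, are the effects of a methoxy group in place of the hydroxy group and of a primary amide in place of the carboxylic acid, both of which stay unchanged across the series.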